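Swapping a difluorophenyl for a trifluoromethylcyclohexyl group

This account rests on a few compounds, and the source may have more. Where it says the series, first, only, none or still open, it means among the compounds named here.

Compound 3 `Fc1ccc(-c2nc3cnc(Nc4ccc(C(F)(F)F)cn4)cc3[nH]2)cc1F` gives 6000 nM in a physicochemical assay for solubility, using the shake flask method, measured as kinetic solubility, with a stated time of 20 h, at pH 2 (a lower number here means a less soluble compound, a higher number a more soluble compound), the lower of the two numbers measured among these compounds. Its nearest neighbour is compound 1 `Fc1ccc(-c2nc3cnc(Nc4ccccn4)cc3[nH]2)cc1F`, which gives 125000 nM; the change a 21-fold lower number from compound 1 to compound 3 (1.32 log units; beyond the scatter). Compound 2 `N#Cc1ccc(Nc2cc3[nH]c(-c4cccc(C(F)(F)F)c4)nc3cn2)nc1` reports only a limit, < 5000 nM, (the limit of < 5000 nM in this assay, at which 1 of the 3 values shown sits).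

Compound 4 `FC(F)(F)c1ccc(Nc2cc3[nH]c([C@H]4CC[C@H](C(F)(F)F)CC4)nc3cn2)nc1` differs from compound 3 in one place: 4-(trifluoromethyl)cyclohexyl in place of 3,4-difluorophenyl on an aromatic carbon. No measured pair among these compounds involves this exchange; the only measured step, that from compound 1 to compound 3, concerns the trifluoromethyl group on the other side of the shared core and does not speak to what a non-aromatic ring in place of an aromatic one does here. With nothing to point in either direction, compound 4 is expected to sit close to compound 3, with the step of no change at the digits printed from compound 3 to compound 4 (within the scatter) expected to stay within the scatter. Compound 4 is therefore estimated at 6000 nM, with a range from 2000 nM to 18000 nM.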

Compound 4, solubility: 200000 nM
For compound 4 the middle estimate is 33-fold (1.52 log units) below the measured one; the whole stated range lies below it.
By their numbers in this assay, from the lowest: compound 3; then compounds 1 and 4 (each within the scatter of the next). At a limit, below all of these: compound 2.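

In this assay the exchange of 3,4-difluorophenyl for 4-(trifluoromethyl)cyclohexyl gives a 33-fold higher number from compound 3 to compound 4 (1.52 log units; beyond the scatter) and so shows that the group on this aromatic carbon, between two ring nitrogen atoms, can move the number strongly. Among the compounds shown here, the only earlier step, a 21-fold lower number from compound 1 to compound 3 (1.32 log units; beyond the scatter) on the other side of the shared core, ran the opposite way, and compound 4 keeps that trifluoromethyl group, so its presence alone does not fix the number at the low level of compound 3. Nothing shown here gives a cause for the new step.

The compounds shown do not separate the loss of the aromatic ring from the added trifluoromethyl group, since plain cyclohexyl does not appear among them. They also leave open how an amine or a carboxylic acid on the same ring would behave at this place.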